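Methoxy to hydroxy on the compound 1 scaffold

The source may report more compounds than this note shows. Statements on the series, on what has been measured and on what is new or still open speak of the compounds shown alone.

Going by the values given here, in a functional assay on cells (Erythrocyte, Homo sapiens) for inhibition, read by spectrophotometry and hemolysis, with a stated time of 10 min (on this read-out higher numbers stand for weaker inhibition and lower numbers for stronger inhibition), compound 1 (`COc1cc(/C=N/NC(=O)CCc2nc3ccccc3c(=O)[nH]2)cc(OC)c1OC`) gives 682000000 nM, the highest of the three numbers measured so far and so the weakest inhibition among them. Compound 3 (`COc1cc(/C=N/NC(=O)CCCc2nc3ccccc3c(=O)[nH]2)cc(O)c1O`) gives 277000000 nM, and compound 2 (`O=C(CCc1nc2ccccc2c(=O)[nH]1)N/N=C/c1ccc(Cl)cc1`) gives 84000000 nM. Both lie lower than compound 1 by more than the scatter, compound 2 by the wider gap.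

The next compound is compound 4 (`COc1cc(/C=N/NC(=O)CCc2nc3ccccc3c(=O)[nH]2)cc(OC)c1O`), which has hydrogen in place of methyl on an oxygen on an aromatic ring. Among the compounds with values here, no measured pair isolates this change. The closest evidence is compound 3, which carries hydroxy as well as methoxy on its aromatic ring and gives 277000000 nM. It differs from compound 1 in more than one place, however, so it is only a loose guide. A modest step to a lower number is expected in this assay, of about the size of the gap between those two compounds, and it could still fall within the scatter. The expected change is a 2.3-fold lower number from compound 1 to compound 4 (0.36 log units; beyond the scatter). The estimate for compound 4 is 300000000 nM, with an expected range from 110000000 nM to 750000000 nM.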

Compound 4, half-maximal inhibitory concentration in the Erythrocyte assay: 530000000 nM
For compound 4 the middle estimate is 1.8-fold (0.25 log units) below the measured one; the measured number falls inside the stated range.
By their numbers in the Erythrocyte assay, from the lowest: compound 2; then compounds 3, 4 and 1 (each within the scatter of the next, the first and the last beyond it).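

Working notes on the series: the methoxy-to-hydroxy change on an oxygen on an aromatic ring now stands alone in one matched pair, which the earlier compounds could not provide, and in the Erythrocyte assay compound 1 gives 682000000 nM and compound 4 gives 530000000 nM so that the change reads as a 1.3-fold lower number from compound 1 to compound 4 (0.11 log units; within the scatter) with no other difference in the structure. In a physicochemical assay, read by spectrophotometry, with a stated time of 6 min (a higher number here means a weaker inhibitor, a lower number a stronger inhibitor), compound 1 gives 55000000 nM and compound 4 gives 105000000 nM so that the same pair reads as a 1.9-fold higher number from compound 1 to compound 4 (0.28 log units; within the scatter) and so also stays inside the usual variation, which means that on the scaffold of compound 1 neither read-out separates hydroxy from methoxy at this position. Nothing available explains why this swap leaves both read-outs within the scatter.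

Open, going by these compounds, is whether another group on this oxygen, such as ethoxy or a longer alkoxy chain, or an amine in place of the hydroxy, would give a step beyond the scatter in either read-out. Also open, on these data alone, is whether a second methoxy-to-hydroxy change on compound 4 would stay within the scatter or whether the effect of such changes builds up on the same ring.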